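From 3,4-dichlorophenyl to 2,3,6-trifluorophenyl on a shared core

The source may report more compounds than this note shows. Statements on the series, on what has been measured and on what is new or still open speak of the compounds shown alone.

Compound 1 `OC[C@H]1O[C@@H](n2cnc3c(NCc4cccc(F)c4)ncnc32)[C@H](O)[C@@H]1O` gives 7600 nM
Compound 2 `OC[C@H]1O[C@@H](n2cnc3c(NCc4ccc(Cl)c(Cl)c4)ncnc32)[C@H](O)[C@@H]1O` gives 10800 nM

Both compounds were tested in a functional assay on K562 cells (Homo sapiens) for antiproliferative activity, with a stated time of 72 h (on this read-out higher numbers stand for weaker inhibition and lower numbers for stronger inhibition), and share the same core. Compound 2, at 10800 nM, lies within the scatter of compound 1 (7600 nM), so neither can be ranked above the other.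

Compound 3 `OC[C@H]1O[C@@H](n2cnc3c(NCc4c(F)ccc(F)c4F)ncnc32)[C@H](O)[C@@H]1O` has not yet been measured. It carries 2,3,6-trifluorophenyl in place of 3,4-dichlorophenyl on a saturated chain carbon bound to a nitrogen on an aromatic ring.

Among the measured compounds shown here, only one measured step bears on this change: a 1.4-fold higher number from compound 1 to compound 2 (0.15 log units; within the scatter), which exchanged 3-fluorophenyl for 3,4-dichlorophenyl at the same place and stayed within the scatter. For the measured compounds named here, no measured compound carries 2,3,6-trifluorophenyl, so this single step is thin evidence and the range must stay wide.

In this assay the expected step is a 1.2-fold lower number from compound 2 to compound 3 (0.08 log units; within the scatter), an estimate that implies no change beyond the scatter in either direction. Compound 3 is expected at 9000 nM (estimated range 3500 nM to 22000 nM).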

Compound 3, half-maximal inhibitory concentration: > 166000 nM
Compound 3 was reported as a limit (the forecaster's own chance of this, stated with the estimate: 10%); at least 18-fold (1.26 log units) between middle value and limit.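

The earlier step between 3-fluorophenyl and 3,4-dichlorophenyl had suggested that this place, on a saturated chain carbon bound to a nitrogen on an aromatic ring, might accept quite different halogenated phenyl groups without a clear change in this assay. The new compound shows that it does not accept all of them: 2,3,6-trifluorophenyl gives an at least 15-fold higher number from compound 2 to compound 3 (1.18 log units; beyond the scatter) and an at least 21-fold higher number from compound 1 to compound 3 (1.33 log units; beyond the scatter), both large and beyond the scatter, so compound 3 is the weakest of the three, and the choice of phenyl group at this place can decide whether any antiproliferative activity is seen at the concentrations reported. The value of compound 3 is a limit and not a number, so these steps give only the least size of the loss: the limit of > 166000 nM in this assay, at which 1 of the 3 values shown sits.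

On these data alone, how far the loss extends stays open, as does which of the three fluorines in 2,3,6-trifluorophenyl goes with it, since the three compounds share no other change that could separate them. As far as these compounds go, whether an unsubstituted phenyl or a methoxyphenyl at this place would fall with compound 1 and compound 2 or with compound 3 also remains unknown.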